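Removing the Isopropyl Side Chain From Compound 2

This account rests on a few compounds, and the source may have more. Where it says the series, first, only, none or still open, it means among the compounds named here.

Measured compounds:
- Compound 1 `CC(=O)N[C@H]1CCN(Cc2ccc(OCCCN(C)C)cc2)C1`; in an assay on HEK293 cells for binding affinity to Urotensin-2 receptor (Homo sapiens), read by radioligand binding (a lower number here means a stronger inhibitor, a higher number a weaker inhibitor), compound 1 gives only a limit of the assay, < 10000 nM.
- Compound 2 `CC(C)[C@H](NC(=O)c1ccc(Cl)c(Cl)c1)C(=O)N[C@H]1CCN(Cc2ccc(OCCCN(C)C)cc2)C1`; in this assay compound 2 gives 794 nM.

Among the measured compounds shown here, compound 2 stands as the sole compound with a true number in this assay; the other value shown, that of compound 1, is a limit and not a number (the limit of < 10000 nM in this assay, at which 1 of the 2 values shown sits). For the measured compounds named here, no pair of measured compounds differs in a single place, so there is no measured step to lean on.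

Compound 3 `CN(C)CCCOc1ccc(CN2CC[C@H](NC(=O)CNC(=O)c3ccc(Cl)c(Cl)c3)C2)cc1` differs from compound 2 in one place: hydrogen in place of isopropyl on a saturated chain carbon bound to an amide-type nitrogen and a carbonyl carbon. The isopropyl branch on that carbon is a sizeable part of what separates compound 2 from compound 1, so its removal is expected to cost affinity by a step beyond the usual scatter, in the weaker direction, amounting to a 4.4-fold higher number from compound 2 to compound 3 (0.64 log units; beyond the scatter).

Compound 3 is therefore estimated at 3500 nM, within a range from 900 nM to 12000 nM, with a real chance that only a limit is reported.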

Compound 3, inhibition constant: < 10000 nM
Compound 3 was reported as a limit; the forecaster's own chance of this, stated with the estimate: 30%; the middle value lies beyond the limit too.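

In this assay compound 3 gives < 10000 nM and that is a limit of the assay, not a number. No step from compound 2 or from compound 1 to compound 3 can be read: the limit of < 10000 nM in this assay, at which 2 of the 3 values shown sit.

Open remains how far compound 3 truly lies from compound 2, and whether the ((3,4-dichlorophenyl)carbonyl)amino group separates compound 3 from compound 1 at all.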